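Chloro for methoxy on the shared core

The compounds below may be only part of what the source reports. "The series", "measured", "known", "first", "only" and "open" are said of these compounds alone.

In an ADME assay for permeability, using PAMPA, at pH 4 (on this read-out higher numbers stand for higher permeability and lower numbers for lower permeability), compound 3 (`COc1ccc2[nH]c(C)c(Cc3ccccc3)c(=O)c2c1`) gives 167 10^-6 cm/s. Compound 1 (`Cc1[nH]c2ccccc2c(=O)c1Cc1ccccc1`) gives 110 10^-6 cm/s, within the scatter of compound 3, while compound 2 (`CCCCC#Cc1c(C)[nH]c2ccc(OC)cc2c1=O`) gives 1020 10^-6 cm/s, well apart on the higher side. Compound 4 (`Cc1[nH]c2ccc(Cl)cc2c(=O)c1Cc1ccccc1`) has chloro in place of methoxy on an aromatic carbon.

Within the data shown here, two measured steps bear on this change. The first, a 1.5-fold higher number from compound 1 to compound 3 (0.18 log units; within the scatter), is methoxy in place of hydrogen on the same aromatic carbon, and it stays within the scatter. The second, a 6.1-fold lower number from compound 2 to compound 3 (0.79 log units; beyond the scatter), goes beyond the scatter, but it is benzyl in place of hex-1-yn-1-yl at a different place, so it says little about this exchange. Among the measured compounds shown here, no measured compound yet carries chloro, which leaves the estimate uncertain. With only the first step as a guide, no change beyond the scatter is expected in this assay. The expected size is a 1.1-fold higher number from compound 3 to compound 4 (0.06 log units; within the scatter). Compound 4 is estimated at 190 10^-6 cm/s, with an expected range of 90 10^-6 cm/s to 400 10^-6 cm/s.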

Compound 4, apparent permeability: 422 10^-6 cm/s
Compound 4: middle estimate off by 2.2-fold (0.35 log units), on the low side, and the stated range ends below it.
By their numbers in this assay, from the lowest: compounds 1 and 3 (each within the scatter of the next); then compound 4; then compound 2.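

The position proved responsive in this assay: chloro in place of methoxy gives a 2.5-fold higher number from compound 3 to compound 4 (0.40 log units; beyond the scatter) and so goes beyond the scatter, whereas the earlier exchange of hydrogen for methoxy at this carbon did not. Chloro in place of hydrogen gives a 3.8-fold higher number from compound 1 to compound 4 (0.58 log units; beyond the scatter) and also goes beyond the scatter, so on the shared core with benzyl, chloro stands apart from both hydrogen and methoxy. Nothing available here accounts for this difference.

As far as these compounds go, it remains open whether bromo, trifluoromethyl or an amine on this aromatic carbon would give a number like that of chloro or like those of hydrogen and methoxy. From the compounds shown here alone, it is also open whether chloro would give a similar step with hex-1-yn-1-yl in place of benzyl.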